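Nitro to Amino on Two Vinylsulfonamide Cores

This account rests on a few compounds, and the source may have more. Where it says the series, first, only, none or still open, it means among the compounds named here.

Measured compounds:
compound 1, `COc1ccc(/C=C/S(=O)(=O)Nc2c(F)c(F)c(F)c(F)c2F)cc1[N+](=O)[O-]`: 100000 nM
compound 2, `COc1ccc(/C=C/S(=O)(=O)Nc2c(F)c(F)c(F)c(F)c2F)cc1N`: 35000 nM
compound 3, `COc1cc(OC)c(/C=C/S(=O)(=O)Nc2ccc(OC)c([N+](=O)[O-])c2)c(OC)c1`: 2500 nM

The three measured compounds were tested in a functional assay on DU-145 cells (Homo sapiens) for cytotoxicity, read by trypan blue exclusion, with a stated time of 96 h; a higher number here means a weaker inhibitor, a lower number a stronger inhibitor. Compound 1 gives 100000 nM in this assay, while compound 2 gives 35000 nM, and compound 3 gives 2500 nM, the lowest of the three numbers. Compound 1 and compound 2 differ in one place, (amino in place of nitro on an aromatic carbon), and that change gave a 2.9-fold lower number from compound 1 to compound 2 (0.46 log units; beyond the scatter). The difference between the core of compound 1 and the core of compound 3 is not broken down here.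

Compound 4, `COc1cc(OC)c(/C=C/S(=O)(=O)Nc2ccc(OC)c(N)c2)c(OC)c1`, has not yet been measured in this assay. Going by the values given here, it differs from compound 3 by amino in place of nitro on an aromatic carbon, which is the same change, at the same kind of place, as the one between compound 1 and compound 2. If that step carries over, compound 4 is expected to show a step from compound 3 of about a 2.5-fold lower number from compound 3 to compound 4 (0.40 log units; beyond the scatter), resting on the single earlier step of a 2.9-fold lower number from compound 1 to compound 2 (0.46 log units; beyond the scatter). The estimate for compound 4 in this assay is 1000 nM, with a range from 300 nM to 3500 nM.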

Compound 4, half-maximal inhibitory concentration: 5 nM
Compound 4: the middle estimate sits 200-fold (2.30 log units) above what was measured; the whole stated range lies above it.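

In this assay, amino in place of nitro on an aromatic carbon gave a 500-fold lower number from compound 3 to compound 4 (2.70 log units; beyond the scatter), so the direction of the earlier step held on the second core while its size did not: the same change on two cores in this assay, a 2.9-fold lower number (0.46 log units; beyond the scatter) from compound 1 to compound 2 and a 500-fold lower number (2.70 log units; beyond the scatter) from compound 3 to compound 4, 180-fold (2.24 log units) apart, beyond the scatter of two such steps

The change thus lowered the number on both cores, but the step seen on the core of compound 1 gave no usable measure of the step on the core of compound 3. Going by these compounds alone, with only two pairs, and with cores that differ in more than one place, these results do not show which part of the core goes with the much larger step, or how large the step would be on a third core.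

The compounds shown leave open whether a hydroxyl group or a methylamino group in the same place would keep the low number of compound 4. They also leave open whether the amino group on the core of compound 3 would give so large a step without the methoxy group it sits ortho to.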